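Moving a hydroxyl on a triaryl-pyridine scaffold

The source may hold more compounds than are shown below. What is called first, only, known or untested is meant among the compounds shown, and "the series" means these compounds.

Compound 1 `Oc1cccc(-c2cc(-c3ccccc3F)cc(-c3ccccc3O)n2)c1` gives 35600 nM in a functional assay on DU-145 cells (Homo sapiens) for inhibition; on this read-out lower numbers stand for stronger inhibition and higher numbers for weaker inhibition. Compound 2 `Oc1cccc(-c2cc(-c3ccccc3F)cc(-c3cccc(O)c3)n2)c1` gives 11200 nM in this assay, and the step of a 3.2-fold lower number from compound 1 to compound 2 (0.50 log units; beyond the scatter) corresponds to the change (3-hydroxyphenyl in place of 2-hydroxyphenyl on an aromatic carbon). Compound 3 `Oc1ccccc1-c1cc(-c2cccc(OC(F)(F)F)c2)cc(-c2ccccc2O)n1` gives 7470 nM in this assay; the difference between the cores of compound 1 and compound 3 is not broken down here. Compound 4 `Oc1cccc(-c2cc(-c3cccc(OC(F)(F)F)c3)cc(-c3ccccc3O)n2)c1` has not been measured; it differs from compound 3 by 3-hydroxyphenyl in place of 2-hydroxyphenyl on an aromatic carbon, the same kind of change as from compound 1 to compound 2, though the place now lies meta to a 2-hydroxyphenyl group and meta to a large group rather than meta to a 2-fluorophenyl group and a 3-hydroxyphenyl group. A step of a 2.5-fold lower number from compound 3 to compound 4 (0.40 log units; beyond the scatter) is expected, slightly smaller than a 3.2-fold lower number from compound 1 to compound 2 (0.50 log units; beyond the scatter) because compound 3 already gives 7470 nM. Compound 4 is estimated at 3000 nM, between 1200 nM and 7500 nM.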

Compound 4, half-maximal inhibitory concentration: > 50000 nM
Compound 4 was reported as a limit; the forecaster's own chance of this, stated with the estimate: 5%; at least 16-fold (1.22 log units) between middle value and limit.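

Replacing 2-hydroxyphenyl with 3-hydroxyphenyl did not carry over from one core to the other in this assay, where the new result is an at least 6.6-fold higher number from compound 3 to compound 4 (0.82 log units; beyond the scatter), and the two steps run in opposite directions: the same change on two cores in this assay, a 3.2-fold lower number (0.50 log units; beyond the scatter) from compound 1 to compound 2 and an at least 6.6-fold higher number (0.82 log units; beyond the scatter) from compound 3 to compound 4, at least 21-fold (1.32 log units) apart, beyond the scatter of two such steps. For compound 4, the value > 50000 nM is a limit of the assay and not a number: the limit of > 50000 nM in this assay, at which 1 of the 4 values shown sits. Within the data shown here, the result shows that the earlier step cannot be relied on for the core of compound 3, but with only one pair on each core it does not show which difference between the cores matters.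

The compounds shown leave open whether an amine or a carboxylic acid in place of the moved hydroxyl would follow either step. They also leave open how the change would read on a core carrying a methoxy group instead of the trifluoromethoxy group.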